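This account rests on a few compounds, and the source may have more. Where it says the series, first, only, none or still open, it means among the compounds named here.

Compound 2 `Cc1ccc(-c2nn(-c3ccc(S(N)(=O)=O)cc3)cc2C(CC(=O)c2ccc(Cl)cc2)C(=O)c2ccc(F)cc2)cc1`: 53.5%
Compound 1 `COc1ccc(-c2nn(-c3ccc(Cl)cc3)cc2C(CC(=O)c2ccc(Cl)cc2)C(=O)c2ccc(F)cc2)cc1`: 19.8%

In a functional assay on the whole organism (strain Wistar albino) for inhibition, with Rattus norvegicus as the target, read by paw edema, with stated times of 1 h and 2 h, at a dose of 0.32 mmol/kg by the intraperitoneal route (on this read-out higher numbers stand for more inhibition at the one dose given (going by the name of the read-out) and lower numbers for less inhibition), compound 2 gives the higher of the two numbers shown, while compound 1 lies far lower, a gap beyond the usual scatter. Compound 3 `COc1ccc(-c2nn(-c3ccc(S(N)(=O)=O)cc3)cc2C(CC(=O)c2ccc(Cl)cc2)C(=O)c2ccc(F)cc2)cc1` has not been measured. It differs from compound 2 in one place: methoxy in place of methyl on an aromatic carbon, which read one bond further out is 4-methylphenyl becoming 4-methoxyphenyl. Among the measured compounds shown here, no measured pair shows this change on its own, so its size is unknown. The step is expected to be small, a number 3.5 percentage points lower from compound 2 to compound 3 (within the scatter), not beyond the scatter. Compound 3 is therefore estimated at 50%, within a range from 35% to 65%.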

Compound 3, a percentage reported as inhibition, in the whole organism at one dose (the size of the read-out at that dose, not a potency): 72.2%
Beside the measured number, compound 3's estimate is 22.2 percentage points below it; measured number outside the range, above it.
By their numbers in this assay, from the lowest: compound 1; then compound 2; then compound 3.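

In this assay the group on this aromatic carbon clearly matters: methoxy in place of methyl, a change of one oxygen atom, gives a step beyond the scatter (a number 18.7 percentage points higher from compound 2 to compound 3 (beyond the scatter)). With methoxy held fixed, sulfamoyl in place of chloro on an aromatic carbon gives a large step (a number 52.4 percentage points higher from compound 1 to compound 3 (beyond the scatter)). Nothing available here says why either step occurs.

Still open, from the compounds shown here alone, is whether a hydroxyl, an amine or a longer chain such as ethoxy at this position would raise or lower the number. Also open, going by these compounds, is whether methoxy would give the same gain over methyl with chloro in place of sulfamoyl.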